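A few compounds are considered here, and "the series" means these few. Any claim that something is new, unique, unknown or untested is made for them only; others in the source may bear on it.

Three compounds of the series are in hand, all in a functional assay on MGC-803 cells (Homo sapiens) for antiproliferative activity, read by CCK-8 assay, with a stated time of 72 h, tested at 2 uM; on this read-out higher numbers stand for a stronger effect at the one concentration tested and lower numbers for a weaker effect: compound 1 `Nc1ccccc1NC(=O)c1ccc(CSC(=S)N2CCN(Cc3ccccn3)CC2)cc1`, compound 2 `CC1CCN(C(=S)SCc2ccc(C(=O)Nc3ccccc3N)cc2)CC1` and compound 3 `CN(Cc1ccncc1)C(=S)SCc1ccc(C(=O)Nc2ccccc2N)cc1`. Compound 1 gives 23.4%, compound 2 gives 28.1% and compound 3 gives 38.1%. On these numbers compound 1 sits lowest of the three; its gap to compound 2 is within the scatter, its gap to compound 3 beyond it. For the measured compounds named here, the only measured step, a number 10 percentage points higher from compound 2 to compound 3 (within the scatter), alters the group on the thiocarbonyl carbon and does not touch the ring nitrogen. Compound 4 `Nc1ccccc1NC(=O)c1ccc(CSC(=S)N2CCN(c3ccncc3)CC2)cc1` differs from compound 1 by pyridin-4-yl in place of (pyridin-2-yl)methyl on an amine nitrogen in a ring. Going by the values given here, no measured step bears on this position, so no step beyond the scatter is expected, a number 3.6 percentage points higher from compound 1 to compound 4 (within the scatter). Compound 4 is therefore estimated at 27%, with a range from 12% to 44%.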

Compound 4, a percentage reported as inhibition, at one concentration (the size of the read-out at that concentration, not a potency): 64.8%
Compound 4: the middle estimate sits 37.8 percentage points below what was measured, outside the stated range (above it).
By their numbers in this assay, from the lowest: compounds 1, 2 and 3 (each within the scatter of the next, the first and the last beyond it); then compound 4.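

For the compounds shown here, the amine nitrogen in the six-membered ring, the site of this change, is the first position to show a large response in this assay: pyridin-4-yl in place of (pyridin-2-yl)methyl gives a number 41.4 percentage points higher from compound 1 to compound 4 (beyond the scatter). Both groups carry a six-membered aromatic ring with one hetero atom, so the count of such rings does not separate them. Nothing available explains the step. The step changes both the methylene link and the attachment point on the pyridine together, so their shares cannot be separated. (Pyridin-4-yl)methyl or pyridin-2-yl on this nitrogen would separate them.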